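Methyl to 1,1-dimethylpropyl on a carbonyl carbon

A few compounds are considered here, and "the series" means these few. Any claim that something is new, unique, unknown or untested is made for them only; others in the source may bear on it.

- Compound 1 `N#Cc1ccc(C(=O)Nc2ccc3nc(NC(=O)C4CCCCC4)sc3c2)cc1`: 3.3 ug/mL
- Compound 2 `O=C(Nc1ccc2nc(NC(=O)C3CCCCC3)sc2c1)c1ccc(Cl)cc1Cl`: > 4 ug/mL, a limit of the assay
- Compound 3 `CC(=O)Nc1ccc2nc(NC(=O)C3CCCCC3)sc2c1`: 2.7 ug/mL

Among the compounds with values here, in a functional assay on WI-38 VA13 cells (Homo sapiens) for cytotoxicity (a lower number here means that less compound is needed, a higher number that more compound is needed for the effect), compound 3 gives 2.7 ug/mL, and its only comparison with a true number is a 1.2-fold lower number from compound 1 to compound 3 (0.09 log units; within the scatter). Compound 4 `CCC(C)(C)C(=O)Nc1ccc2nc(NC(=O)C3CCCCC3)sc2c1` carries 1,1-dimethylpropyl in place of methyl on a carbonyl carbon. Two measured exchanges at this same place bear on it: a 1.2-fold lower number from compound 1 to compound 3 (0.09 log units; within the scatter), and an at least 1.4-fold lower number from compound 2 to compound 3 (0.17 log units; that floor lies within the scatter). Neither shows a change beyond the scatter, so no step beyond the scatter is expected here either. The expected step is a 1.1-fold higher number from compound 3 to compound 4 (0.05 log units; within the scatter). For compound 4 the estimated value is 3 ug/mL, with an expected range of 1.5 ug/mL to 5.5 ug/mL.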

Compound 4, half-maximal effective concentration: 1 ug/mL
The estimate for compound 4 lay 3.0-fold (0.48 log units) above the measured number; measured number outside the range, below it.
By their numbers in this assay, from the lowest: compound 4; then compounds 3 and 1 (each within the scatter of the next). At a limit, above all of these: compound 2.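

In this assay, the place on the carbonyl carbon, where the earlier exchanges stayed within the scatter, now gives a step beyond it: a 2.7-fold lower number from compound 3 to compound 4 (0.43 log units; beyond the scatter). The 1,1-dimethylpropyl group also stands apart from both aromatic groups, with a 3.3-fold lower number from compound 1 to compound 4 (0.52 log units; beyond the scatter) and an at least 4.0-fold lower number from compound 2 to compound 4 (0.60 log units; beyond the scatter). The last of these steps is only a floor, as compound 2 carries a limit and not a number: the limit of > 4 ug/mL in this assay, at which 1 of the 4 values shown sits.

The compounds shown leave open whether a straight pentyl chain or a tert-butyl group on this carbonyl carbon would give a similar number. They also leave open whether branching or chain length matters here.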